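Triazole-linked amide chains on the shared core

The source may hold more compounds than are shown below. What is called first, only, known or untested is meant among the compounds shown, and "the series" means these compounds.

The series shares the core of compound 1 `O=C(NCc1cnnn1Cc1ccc2oc(-c3ccc(Cl)cc3)cc(=O)c2c1)c1ccccc1` and varies the group carried on the triazole. In an assay on isolated protein for inhibition of Amine oxidase [flavin-containing] B (Homo sapiens), read by fluorescence and spectrophotometry (a lower number here means a stronger inhibitor, a higher number a weaker inhibitor), compound 1 gives 32900 nM. Compound 2 `Cc1ccc(NC(=O)CCCCc2cn(Cc3ccc4oc(-c5ccc(Cl)cc5)cc(=O)c4c3)nn2)cc1` carries a longer amide chain, and in this assay compound 2 gives 32900 nM, level with compound 1 within the scatter. Compound 3 `Cc1ccc(NC(=O)CCc2cn(Cc3ccc4oc(-c5ccc(Cl)cc5)cc(=O)c4c3)nn2)cc1` differs from compound 2 by a group of 10 heavy atoms (8 carbon, 1 nitrogen, 1 oxygen; one six-membered aromatic ring of carbon only) in place of a group of 12 heavy atoms (10 carbon, 1 nitrogen, 1 oxygen; one six-membered aromatic ring of carbon only), on a saturated chain carbon, two bonds along the chain from an aromatic carbon. Going by the values given here, with only two measured compounds, both at the same level, no change beyond the scatter is expected for the step of a 1.0-fold higher number from compound 2 to compound 3 (0.00 log units; within the scatter). Compound 3 is therefore estimated at 33000 nM, within a range of 15000 nM to 70000 nM.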

Compound 3, half-maximal inhibitory concentration: 32900 nM
Compound 3: the middle estimate sits 1.0-fold (0.00 log units) above what was measured; low and high end bracket the measured number.
By their numbers in this assay, from the lowest: compounds 1, 2 and 3 (each within the scatter of the next).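

In this assay, placing (4-methylphenyl)carbamoyl on the saturated chain carbon, in place of the group of 12 heavy atoms, gives no change at the digits printed from compound 2 to compound 3 (within the scatter). At this position, the two chain lengths carrying the same methylphenyl amide therefore read alike, which compounds 1 and 2 alone, differing in more than one place, could not show. No supporting evidence bears on this result.

Still open, on these data alone, is whether any group at this position separates from this level. A carboxylic acid or an amine in place of the amide, or a chlorine in place of the ring methyl, would test this.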